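This account rests on a few compounds, and the source may have more. Where it says the series, first, only, none or still open, it means among the compounds named here.

Compound 1, `NC(=O)[C@@H]1[C@H](Nc2nc(Nc3cccc(C(=O)N4CCCC4)c3)ncc2C2CC2)[C@H]2C=C[C@@H]1C2`: 90 nM in a functional assay on THP-1 cells (Homo sapiens) for inhibition, read by ELISA, with stated times of 1 h and 18 h; a lower number here means a stronger inhibitor, a higher number a weaker inhibitor
Compound 2, `NC(=O)[C@@H]1[C@H](Nc2nc(Nc3cccc(C(=O)N4CCCC4)c3)ncc2-c2ccoc2)[C@H]2C=C[C@@H]1C2`: 40 nM
Compound 3, `NC(=O)[C@@H]1[C@H](Nc2nc(Nc3cccc(C(=O)N4CCCC4)c3)ncc2-c2ccc(F)cc2)[C@H]2C=C[C@@H]1C2`: 460 nM

Compound 2 holds the lowest number of the three in this assay; compound 1 is the nearest to it, at a 2.3-fold lower number from compound 1 to compound 2 (0.35 log units; beyond the scatter), and compound 3 the furthest, at a 12-fold higher number from compound 2 to compound 3 (1.06 log units; beyond the scatter). Compound 4, `N#Cc1ccc(-c2cnc(Nc3cccc(C(=O)N4CCCC4)c3)nc2N[C@H]2[C@@H](C(N)=O)[C@@H]3C=C[C@H]2C3)cc1`, has not yet been measured in this assay. It differs from compound 2 at one place: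

4-cyanophenyl in place of furan-3-yl on an aromatic carbon

The step that bears most directly on this change is a 12-fold higher number from compound 2 to compound 3 (1.06 log units; beyond the scatter), where a six-membered aromatic ring of carbon only also took the place of the furan-3-yl on the same aromatic carbon. The related step of a 5.1-fold higher number from compound 1 to compound 3 (0.71 log units; beyond the scatter) points the same way. For the measured compounds named here, compound 4 carries 4-cyanophenyl rather than 4-fluorophenyl, and no measured pair shows what that exchange does, so the expectation rests on the furan-to-phenyl steps alone. Compound 4 is therefore expected to give a higher number than compound 2 in this assay, with a step of about a 10-fold higher number from compound 2 to compound 4 (1.00 log units; beyond the scatter). Compound 4 is estimated at 400 nM, within a range of 150 nM to 1200 nM.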

Compound 4, half-maximal inhibitory concentration: 190 nM
Compound 4: the middle estimate sits 2.1-fold (0.32 log units) above what was measured, within the range that was stated.
By their numbers in this assay, from the lowest: compound 2; then compound 1; then compound 4; then compound 3.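

In this assay the exchange of fluoro for cyano gives a 2.4-fold lower number from compound 3 to compound 4 (0.38 log units; beyond the scatter) and so shows that, at this position, the result depends on the substituent carried by the six-membered aromatic ring and not on that ring alone. That gain does not close the gap to the earlier groups: furan-3-yl gives way to 4-cyanophenyl with a 4.8-fold higher number from compound 2 to compound 4 (0.68 log units; beyond the scatter) and cyclopropyl gives way to it with a 2.1-fold higher number from compound 1 to compound 4 (0.32 log units; beyond the scatter) so both compounds with the six-membered ring, compound 3 and compound 4, have higher numbers than compound 1 and compound 2. No measurement at hand accounts for these differences. The compounds shown leave open what unsubstituted phenyl would give, and whether an amine or a carboxylic acid in place of the cyano group would bring the number closer to that of compound 2.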